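The source may hold more compounds than are shown below. What is called first, only, known or untested is meant among the compounds shown, and "the series" means these compounds.

In a toxicity assay on A549 cells (Homo sapiens) for cytotoxicity, read by luminescence and CellTiter-Glo, with a stated time of 48 h (a lower number here means that less compound is tolerated, a higher number that more compound is tolerated), compound 1 `CCCCOc1ccc(-c2nc3ncccn3c2N)cc1` gives > 100000 nM, which is a limit of the assay. Compound 2 `CCNC(=O)CCCOc1ccc(-c2nc3ncccn3c2NC2CCCCC2)cc1` gives > 100000 nM, again a limit and not a number. Compound 2 therefore has no exact position, and the measured series stands at the limit of > 100000 nM in this assay, at which 2 of the 2 values shown sit. Compound 3 `Fc1ccc(-c2nc3ncccn3c2NC2CCCCC2)cc1` differs from compound 2 by one change, fluoro in place of 3-(ethylcarbamoyl)propoxy on an aromatic carbon, para to a large group: fluoro in place of 3-(ethylcarbamoyl)propoxy on an aromatic carbon. Going by the values given here, no measured step covers this change, so no step beyond the scatter is expected in this assay, and the estimated step is an at least 1.2-fold lower number from compound 2 to compound 3 (0.09 log units; that floor lies within the scatter). Compound 3 is estimated at 80000 nM, with an expected range of 30000 nM to 100000 nM.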

Compound 3, half-maximal cytotoxic concentration: 100000 nM
Beside the measured number, compound 3's estimate is 1.3-fold (0.10 log units) below it; the measured number falls inside the stated range.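

In this assay, going by these compounds alone, compound 3 gives 100000 nM, the first exact number, with fluoro on the aromatic carbon para to a large group. Compound 2, with 3-(ethylcarbamoyl)propoxy at that place, gives > 100000 nM, which is a limit and not a number. The swap of this long chain for fluoro therefore gives a number no higher from compound 2 to compound 3 (the limit leaves the size open), with most of the series still at the limit: the limit of > 100000 nM in this assay, at which 2 of the 3 values shown sit.

From the compounds shown here alone, whether an amine or a carboxylic acid on this aromatic carbon would give a clearly lower number stays open.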